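The compounds below may be only part of what the source reports. "The series", "measured", "known", "first", "only" and "open" are said of these compounds alone.

The measured compounds so far:

Compound 1, `O=C(O)CCCC/C=C(\c1cccnc1)c1cccs1`, gives 20 nM in an assay (Equus caballus) for inhibition of Thromboxane-A synthase (Homo sapiens), using microsomes; on this read-out higher numbers stand for weaker inhibition and lower numbers for stronger inhibition.
Compound 2, `O=C(O)CCCC/C=C(\c1cccnc1)c1cccc(F)c1`, gives 55 nM in this assay.

Among these two numbers compound 2 stands highest, meaning the weaker inhibition of the pair. Among the compounds with values here, its only neighbour is compound 1, and the step between them is a 2.8-fold higher number from compound 1 to compound 2 (0.44 log units; beyond the scatter), a change in which the whole ring on the double-bonded chain carbon was exchanged.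

The next compound, compound 3, `O=C(O)CCCC/C=C(\c1cccnc1)c1ccccc1Br`, is not yet measured. It differs from compound 2 in one place: 2-bromophenyl in place of 3-fluorophenyl on a double-bonded chain carbon bound to an aromatic carbon and a double-bonded chain carbon.

Within the data shown here, no measured step has the same shape as this one. Among the measured compounds shown here, the single step available swaps thiophen-2-yl for 3-fluorophenyl, whereas here one halogen-bearing phenyl ring replaces another, so that step gives only a rough sense of how far a ring exchange at this position can move the number. With nothing pointing in either direction, the expectation is a step within the scatter, a 1.1-fold higher number from compound 2 to compound 3 (0.04 log units; within the scatter), with a wide margin on both sides. Compound 3 is therefore estimated at 60 nM, with a likely range from 20 nM to 200 nM.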

Compound 3, half-maximal inhibitory concentration: 130 nM
For compound 3 the middle estimate is 2.2-fold (0.34 log units) below the measured one, within the range that was stated.
By their numbers in this assay, from the lowest: compound 1; then compound 2; then compound 3.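

Exchanging one halogen-bearing phenyl ring for another at this double-bonded chain carbon is not a silent change: in this assay it gives a 2.4-fold higher number from compound 2 to compound 3 (0.37 log units; beyond the scatter), although 3-fluorophenyl and 2-bromophenyl have the same count of heavy atoms and neither has a hydrogen-bond donor or acceptor. The position therefore responds to what the ring carries, not only to which kind of ring is present, and the spread is wider than the first pair suggested, with a 6.5-fold higher number from compound 1 to compound 3 (0.81 log units; beyond the scatter) across the three compounds, so that the thiophen-2-yl compound keeps the lowest number. Nothing available explains why the numbers move this way at this position.

The step from compound 2 to compound 3 changes both the halogen and its numbered place on the ring, so these compounds cannot show which of the two matters, or how much each contributes. Also open, on these data alone, is where a plain phenyl ring without any halogen, or a phenyl ring carrying a methyl group, would fall relative to these three compounds.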